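Exchanging the aromatic ring on compound 2

The source may hold more compounds than are shown below. What is called first, only, known or untested is meant among the compounds shown, and "the series" means these compounds.

Measured compounds:
compound 1 `O=C(O)c1ccc(C(=O)/C(=C\c2ccc(Br)c([N+](=O)[O-])c2)SCc2ccccc2Cl)cc1` – 1000 nM
compound 2 `Cc1cc(C)cc(/C=C(/SCc2ccc(F)cc2)C(=O)c2ccc(Br)cc2)c1` – 10000 nM
compound 3 `COc1ccc(OC)c(/C=C(/SCc2ccc(Cl)c(Cl)c2)C(=O)c2ccc(Cl)cc2)c1` – 10000 nM

In a functional assay on DU-145 cells (Homo sapiens) for inhibition, read by trypan blue exclusion, with a stated time of 96 h (a higher number here means a weaker inhibitor of growth, a lower number a stronger inhibitor of growth), compound 2 gives 10000 nM, level with compound 3 at the digits shown, and these two together are the highest of the three numbers. Compound 1 gives the lowest number, a gap beyond the scatter. Compound 4 `Cc1ccsc1/C=C(/SCc1ccc(F)cc1)C(=O)c1ccc(Br)cc1` is not yet measured; it differs from compound 2 in one place: 3-methylthiophen-2-yl in place of 3,5-dimethylphenyl on a double-bonded chain carbon bound to a double-bonded chain carbon. For the measured compounds named here, no measured pair shows this exchange, so nothing indicates its size. In this assay the step is expected to stay within the scatter, no change at the digits printed from compound 2 to compound 4 (within the scatter). Compound 4 is therefore estimated at 10000 nM, with a range from 3000 nM to 30000 nM.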

Compound 4, concentration for 50% growth inhibition: 50000 nM
For compound 4 the middle estimate is 5.0-fold (0.70 log units) below the measured one, outside the stated range (above it).
By their numbers in this assay, from the lowest: compound 1; then compounds 2 and 3 (each within the scatter of the next); then compound 4.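

For the compounds shown here, this is the first exchange at this position that can be read, and in this assay the ring proves not to be interchangeable: 3-methylthiophen-2-yl in place of 3,5-dimethylphenyl gives a 5.0-fold higher number from compound 2 to compound 4 (0.70 log units; beyond the scatter), a weaker inhibitor of growth. The earlier compounds shown here could not show this, since none of them forms a one-place pair. Nothing available accounts for the step.

Going by these compounds alone, the single step does not separate the change of ring from the change in methyl groups. From the compounds shown here alone, how an unsubstituted thiophen-2-yl, a plain phenyl or a pyridin-2-yl would compare with compound 2 and compound 4 remains open.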